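Removing a Trifluoromethyl Group from a Weak Growth Inhibitor

The source may report more compounds than this note shows. Statements on the series, on what has been measured and on what is new or still open speak of the compounds shown alone.

Measured so far in a functional assay on COLO 205 cells (Homo sapiens) for inhibition, read by sulforhodamine B assay; a lower number here means a stronger inhibitor of growth, a higher number a weaker inhibitor of growth:
- compound 1, `Oc1cccc2[nH]c(-c3ccc(-c4ccc(-c5ccc(OC(F)(F)F)cc5)cc4)cc3)nc12`, gives 8320 nM
- compound 2, `Oc1ccc(-c2ccc(-c3ccc(-c4nc5c(O)cccc5[nH]4)cc3)cc2)cc1`, gives 2600 nM
- compound 3, `Cc1ccc2[nH]c(-c3ccc(-c4ccc(-c5ccc(OC(F)(F)F)cc5)cc4)cc3)nc2c1`, gives 30600 nM

Compound 4, `Cc1ccc2[nH]c(-c3ccc(-c4ccc(-c5ccc(O)cc5)cc4)cc3)nc2c1`, has not yet been measured in this assay. It differs from compound 3 by one change, (hydrogen in place of trifluoromethyl on an oxygen on an aromatic ring). The same change has already been seen once, between compound 1 and compound 2, where it is counted as hydrogen in place of trifluoromethyl on an oxygen on an aromatic ring and gave a 3.2-fold lower number from compound 1 to compound 2 (0.51 log units; beyond the scatter). The place of the change is described in the same words in both cases, so it is the same change made on a different core.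

The two cores differ as 5-methyl-1H-benzimidazol-2-yl in place of 4-hydroxy-1H-benzimidazol-2-yl on an aromatic carbon, and that difference gave a 3.7-fold higher number from compound 1 to compound 3 (0.57 log units; beyond the scatter), leaving compound 3 with the highest number of the three. Going by the values given here, whether the gain seen from compound 1 to compound 2 carries over onto the core of compound 3 is not known, but since it is the only comparable step available, a similar step is expected: a 3.2-fold lower number from compound 3 to compound 4 (0.51 log units; beyond the scatter). Compound 4 is therefore estimated at 9500 nM, most likely between 3000 nM and 30000 nM.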

Compound 4, concentration for 50% growth inhibition: 100000 nM
The estimate for compound 4 lay 11-fold (1.02 log units) below the measured number; measured number above the stated range.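

Replacing trifluoromethyl with hydrogen on the oxygen did not carry over from one core to the other: in this assay the change gave a 3.3-fold higher number from compound 3 to compound 4 (0.51 log units; beyond the scatter) and so ran the opposite way to the earlier step on the core of compound 1. The two steps have about the same size but opposite directions, and they differ by more than the scatter allows: the same change on two cores in this assay, a 3.2-fold lower number (0.51 log units; beyond the scatter) from compound 1 to compound 2 and a 3.3-fold higher number (0.51 log units; beyond the scatter) from compound 3 to compound 4, 10-fold (1.02 log units) apart, beyond the scatter of two such steps. This shows that in these four compounds the outcome of the change depends on the core carrying it, so a step seen on one core is a poor guide to the other, but it does not show why the direction reverses or which way the change would go on a third core.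

The compounds shown leave open how a methoxy group, an amine or a longer chain would behave in place of the trifluoromethoxy group. They also leave open whether either direction would hold on a core carrying a different group, such as a carboxylic acid, in place of the hydroxy or methyl.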